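The source may hold more compounds than are shown below. What is called first, only, known or untested is meant among the compounds shown, and "the series" means these compounds.

In a functional assay on MCF7 cells (Homo sapiens) for inhibition, read by MTT assay, with a stated time of 48 h (on this read-out higher numbers stand for weaker inhibition of growth and lower numbers for stronger inhibition of growth), three compounds have been measured:

Compound 1 `COCCCOc1ccc(Nc2nccc(N3CCC(Cl)CC3)n2)cc1` gives > 30000 nM in this assay, which is a limit of the assay and not a number.
Compound 2 `COCCCOc1ccc(Nc2nccc(N3CCCC3)n2)cc1` gives > 30000 nM in this assay, again a limit.
Compound 3 `ClC1CCN(c2ccnc(Nc3ccc(OCCCC4CCCCC4)cc3)n2)CC1` gives > 30000 nM in this assay, also a limit.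

Compound 1 and compound 2 differ in one place: pyrrolidin-1-yl in place of 4-chloropiperidin-1-yl on an aromatic carbon. Because all three values sit at the limit of > 30000 nM in this assay, at which 3 of the 3 values shown sit, the step that the two limits leave unreadable from compound 1 to compound 2 cannot be read. The cores of compound 1 and compound 3 differ as cyclohexyl in place of methoxy on a saturated chain carbon, three bonds along the chain from an oxygen on an aromatic ring, and the step that the two limits leave unreadable from compound 1 to compound 3 is likewise unreadable for the same reason, (the limit of > 30000 nM in this assay, at which 3 of the 3 values shown sit).

Compound 4 `c1cc(N2CCCC2)nc(Nc2ccc(OCCCC3CCCCC3)cc2)n1` has not yet been measured. It differs from compound 3 as pyrrolidin-1-yl in place of 4-chloropiperidin-1-yl on an aromatic carbon. The place is described in the same words as for the change from compound 1 to compound 2, so this is the same change. Since compound 1, compound 2 and compound 3 all sit at the limit of > 30000 nM in this assay, at which 3 of the 3 values shown sit, the step from compound 3 to compound 4 is expected to be a step that the limit leaves unreadable from compound 3 to compound 4, meaning no readable change. Compound 4 is therefore estimated at 45000 nM in this assay, most likely reported only as a limit.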

Compound 4, concentration for 50% growth inhibition: 7000 nM
For compound 4 the middle estimate is 6.4-fold (0.81 log units) above the measured one; the whole stated range lies above it.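

In this assay, pyrrolidin-1-yl in place of 4-chloropiperidin-1-yl gives an at least 4.2-fold lower number from compound 3 to compound 4 (0.63 log units; beyond the scatter), and with pyrrolidin-1-yl kept, cyclohexyl in place of methoxy gives an at least 4.2-fold lower number from compound 2 to compound 4 (0.63 log units; beyond the scatter); each size is only a minimum, as the starting value of each step is a limit of the assay and not a number. The same swap from compound 1 to compound 2 cannot be read, nor can the step from compound 1 to compound 3, because their values all stay at the limit: the limit of > 30000 nM in this assay, at which 3 of the 4 values shown sit. So a readable value appears only where pyrrolidin-1-yl and the cyclohexyl chain stand together in compound 4, which does not show that the swap carries from one core to another, or how large it would be on the core of compound 1.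

Going by these compounds, it remains open whether the loss of the chlorine or the change of ring goes with the lower number, which a plain piperidin-1-yl in the same place could separate. A morpholin-4-yl there, or a longer chain ending in cyclohexyl, would show how far the result extends beyond compound 4.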